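The source may report more compounds than this note shows. Statements on the series, on what has been measured and on what is new or still open speak of the compounds shown alone.

Working notes on the series.

The series is examined in an assay on cells for inhibition of Amine oxidase [flavin-containing] B (Homo sapiens), read by fluorescence, with stated times of 30 min and 15 min, tested at 1 uM; on this read-out higher numbers stand for more inhibition at the one concentration tested (going by the name of the read-out) and lower numbers for less inhibition. For the measured compounds named here, compound 1, `Cn1c(=O)[nH]c2ccc(OCCc3cccc(Cl)c3)cc21`, is the only member with a number on this read-out: in this assay compound 1 gives 13.7%. Compound 2, `Cn1c(=O)[nH]c2cc(OCCc3ccccc3)ccc21`, gives "not active" (no number reported) in this assay. Compound 3, `CC(C)=C1C(=O)Nc2ccc(OCCc3ccccc3)cc21`, gives "not active" (no number reported) in this assay. Compound 1 thus stands alone with a number, and that number is itself a modest one at the single concentration tested; the other two entries carry no number at all.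

Compound 4, `Cn1c(=O)[nH]c2ccc(OCCc3ccccc3)cc21`, has not been measured. It differs from compound 1 as follows: hydrogen in place of chloro on an aromatic carbon. Going by the values given here, the change sits on an aromatic carbon of a six-membered aromatic ring of carbon only, meta to a large group, and the chloro is the only feature that separates compound 1 from compound 4.

Among the compounds with values here, no measured pair in the set shares this exact change, so the size of the step is not known from data. Within the data shown here, the two compounds without a number, compound 2 and compound 3, both lack a chloro, and compound 1 with its chloro is the only one with a reported number. The expectation for compound 4 is therefore a step downward, of a size that may or may not pass beyond the scatter, with a real chance that the read-out is reported without a number. The estimate for compound 4 in this assay is 5%, with a range from -5% to 14%, which is expected to correspond to a step of a number 8.7 percentage points lower from compound 1 to compound 4 (within the scatter).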

Compound 4, a percentage reported as inhibition, at one concentration (the size of the read-out at that concentration, not a potency): "not active" (no number reported)
Compound 4 has no reported number here; no gap can be computed for the estimate.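

In this assay, for the compounds shown here, compound 4 is reported without a number, so no step from compound 1 to compound 4 can be read. The compounds shown leave open how much the change from 3-chlorophenyl to phenyl shifts the read-out in this assay, if at all. No available evidence bears on this result.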